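Epimer Swap at a Ring Carbon: Any Shift in Cytotoxicity?

A few compounds are considered here, and "the series" means these few. Any claim that something is new, unique, unknown or untested is made for them only; others in the source may bear on it.

Three glycal-type sulfonamides sharing one core were tested in a functional assay on HepG2 cells (Homo sapiens) for cytotoxicity, read by MTT assay, with a stated time of 48 h; a higher number here means a weaker inhibitor, a lower number a stronger inhibitor. Compound 1, `CC(=O)OC[C@H]1O[C@H](NS(=O)(=O)c2ccc(C)cc2)C=C[C@H]1OC(C)=O`, gives 307000000 nM. Compound 2, `CC(=O)OC[C@H]1O[C@H](NS(N)(=O)=O)C=C[C@H]1OC(C)=O`, gives 304000000 nM; the step of a 1.0-fold lower number from compound 1 to compound 2 (0.00 log units; within the scatter) shows the change at the sulfonyl sulfur left the number unmoved. Compound 3, `CCS(=O)(=O)N[C@@H]1C=C[C@H](OC(C)=O)[C@@H](COC(C)=O)O1`, gives 231000000 nM, a figure that sits within the scatter of both compound 1 and compound 2, so none of the three can be separated on this assay.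

Compound 4, `CCS(=O)(=O)N[C@@H]1C=C[C@@H](OC(C)=O)[C@@H](COC(C)=O)O1`, is the next member. Its relation to compound 3 is the two compounds have the same atoms and bonds and differ only in configuration as drawn: 1 of 3 stereo elements differ; a stereocentre at a saturated ring carbon is drawn S in compound 3 and R in compound 4. Within the data shown here, no measured step among the three touches a stereocentre; the only step on record, from compound 1 to compound 2, concerns a substituent and was flat. Among the measured compounds shown here, with no precedent for an inversion and a dataset in which every change so far fell within the scatter, the expected step of a 1.1-fold higher number from compound 3 to compound 4 (0.03 log units; within the scatter) is none beyond the scatter. Compound 4 is therefore estimated at 250000000 nM, with a range of 100000000 nM to 600000000 nM.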

Compound 4, half-maximal inhibitory concentration: 192000000 nM
The estimate for compound 4 lay 1.3-fold (0.11 log units) above the measured number; the measured number falls inside the stated range.
By their numbers in this assay, from the lowest: compounds 4, 3, 2 and 1 (each within the scatter of the next).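

Among these compounds, the only change of configuration in the set gives, in this assay, a 1.2-fold lower number from compound 3 to compound 4 (0.08 log units; within the scatter), so inverting this saturated ring carbon does not separate the two compounds, and a stereocentre proves as flat here as the substituent step did earlier. The comparison is a clean one for this single centre: the fact that compounds 3 and 4 differ only in the configuration as drawn. With the inverted centre in place the sulfonyl substituent still does not separate the compounds, since ethyl in place of amino gives a 1.6-fold lower number from compound 2 to compound 4 (0.20 log units; within the scatter) and ethyl in place of 4-methylphenyl gives a 1.6-fold lower number from compound 1 to compound 4 (0.20 log units; within the scatter).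

The compounds shown leave open whether inverting either of the other two stereocentres would move the number beyond the scatter. They also leave open whether a free hydroxyl in place of an acetate, or a carboxylic acid or a longer chain on the sulfonyl sulfur, would do so.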